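The compounds below may be only part of what the source reports. "The series", "measured", "known", "first", "only" and "open" are said of these compounds alone.

Compound 2 `CCC(C)(C)Cc1c[nH]c(CCc2ccc(-c3ccc(F)cn3)cc2)n1` gives 16 nM in a functional assay on HEK293 cells for agonist activity at Bombesin receptor subtype-3 (Mus musculus), read by luminescence and calcium flux, with a stated time of 10 min; on this read-out higher numbers stand for an effect only at larger amounts of compound and lower numbers for an effect already at smaller amounts; its number is the higher of the two measured, yet compound 1 `CCC(C)(C)Cc1c[nH]c(CCc2ccc(-c3ccncc3)cc2)n1`, with 15 nM, lies within the scatter of it, as the step of a 1.1-fold higher number from compound 1 to compound 2 (0.03 log units; within the scatter) shows. Compound 3 `CCC(C)(C)Cc1c[nH]c(CCc2ccc(-c3csnn3)cc2)n1` carries the change (1,2,3-thiadiazol-4-yl in place of 5-fluoropyridin-2-yl on an aromatic carbon). Within the data shown here, the only measured step, from compound 1 to compound 2, also swapped one aromatic ring for another and stayed within the scatter, so for compound 3 a small shift in this assay is expected, a 1.9-fold higher number from compound 2 to compound 3 (0.27 log units; within the scatter). Compound 3 is thus estimated at 30 nM, with a range from 8 nM to 120 nM.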

Compound 3, half-maximal effective concentration: 11 nM
Compound 3: middle estimate off by 2.7-fold (0.44 log units), on the high side; measured number inside the range.
By their numbers in this assay, from the lowest: compounds 3, 1 and 2 (each within the scatter of the next).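

In this assay, among these compounds, a five-membered aromatic ring now stands on the aromatic carbon para to a large group, where the earlier compounds carried six-membered aromatic rings, and the result is a 1.5-fold lower number from compound 2 to compound 3 (0.16 log units; within the scatter) and a 1.4-fold lower number from compound 1 to compound 3 (0.13 log units; within the scatter). At this position, then, the change in ring size and in the number of hetero atoms leaves the number within the scatter. Nothing available explains this result. From the compounds shown here alone, all three groups are aromatic rings, so it remains open whether a morpholine, a carboxylic acid or a simple alkyl chain at this position would keep the number in this range.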